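Replacing 4-fluorophenyl with naphthalen-2-yl on a shared core

The source may hold more compounds than are shown below. What is called first, only, known or untested is meant among the compounds shown, and "the series" means these compounds.

Compound 1 `N=C(N)c1ccc2[nH]c(-c3ccc4nc(-c5ccc(F)cc5)[nH]c4c3)nc2c1`: 2.48 ug/mL
Compound 2 `COc1cc(-c2nc3ccc(-c4nc5cc(C(=N)N)ccc5[nH]4)cc3[nH]2)ccc1OCc1ccccc1`: 19.8 ug/mL

In an ADME assay on L6 cells (Rattus norvegicus) for cytotoxicity, read by resazurin assay (on this read-out higher numbers stand for weaker inhibition and lower numbers for stronger inhibition), compound 1 has the lower of the two numbers at 2.48 ug/mL, and compound 2 gives 19.8 ug/mL, a gap that lies beyond the usual scatter. Compound 3 `N=C(N)c1ccc2[nH]c(-c3ccc4nc(-c5ccc6ccccc6c5)[nH]c4c3)nc2c1` keeps the core of compound 1 but carries naphthalen-2-yl in place of 4-fluorophenyl on an aromatic carbon. Among the measured compounds shown here, no measured pair shows this exact change, so the forecast is uncertain. A small rise in the number is expected in this assay, an estimated step of a 1.4-fold higher number from compound 1 to compound 3 (0.15 log units; within the scatter), and it may not exceed the scatter. For compound 3 the estimated value is 3.5 ug/mL, with an expected range from 1.1 ug/mL to 12 ug/mL.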

Compound 3, half-maximal inhibitory concentration: 34.7 ug/mL
For compound 3 the middle estimate is 9.9-fold (1.00 log units) below the measured one; the whole stated range lies below it.
By their numbers in this assay, from the lowest: compound 1; then compounds 2 and 3 (each within the scatter of the next).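

At this aromatic carbon, the choice of ring group clearly matters: in this assay, naphthalen-2-yl in place of 4-fluorophenyl gives a 14-fold higher number from compound 1 to compound 3 (1.15 log units; beyond the scatter) and so much weaker inhibition of the cells. Among the compounds shown here, this single step shows that changing only this group on the shared core can move the number well beyond the scatter. No available evidence explains the shift. From the compounds shown here alone, whether the fluorine or the second carbon ring matters more remains open. So does the effect of a plain phenyl or a phenyl carrying an amine or carboxylic acid.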